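The source may report more compounds than this note shows. Statements on the series, on what has been measured and on what is new or still open speak of the compounds shown alone.

Series notes. Compound 3, `Cc1cc(NC(=O)Nc2ccc(N)cc2)c2ccccc2n1`, carries an amino group on an aromatic carbon where compound 1, `COc1ccc(NC(=O)Nc2cc(C)nc3ccccc23)cc1`, carries methoxy and compound 2, `Cc1ccc(NC(=O)Nc2cc(C)nc3ccccc23)cc1`, carries methyl. In an ADME assay on Raji cells (Homo sapiens) for cytotoxicity, with a stated time of 72 h (a lower number here means that less compound is needed, a higher number that more compound is needed for the effect), compound 1 gives only a limit, > 25000 nM. In this assay compound 2 likewise gives a limit, > 25000 nM. In this assay compound 3 also gives a limit, > 25000 nM. Compound 3 thus stands at the limit shared by every value in the set, (the limit of > 25000 nM in this assay, at which 3 of the 3 values shown sit). Among the measured compounds shown here, none of the measured steps can be read: a step that the two limits leave unreadable from compound 1 to compound 2, a step that the two limits leave unreadable from compound 1 to compound 3 and a step that the two limits leave unreadable from compound 2 to compound 3. Compound 4, `Cc1cc(NC(=O)Nc2ccc(F)cc2)c2ccccc2n1`, differs from compound 3 by fluoro in place of amino on an aromatic carbon. With no readable step among the three measured compounds, no step beyond the scatter is expected in this assay in either direction, and a further limit is the most probable result. Compound 4 is expected to give about 35000 nM in this assay, between 10000 nM and 120000 nM. The expected step that the limit leaves unreadable from compound 3 to compound 4 is accordingly judged unreadable against the limits.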

Compound 4, half-maximal effective concentration: > 25000 nM
Compound 4 gave a limit, no number; the forecaster's own chance of this, stated with the estimate: 85%; the middle value is on the limit's open side.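

Among the compounds shown here, no step to compound 4 from compound 1, compound 2 or compound 3 can be read in this assay, and all four compounds share one limit: the limit of > 25000 nM in this assay, at which 4 of the 4 values shown sit. The compounds shown leave open whether any change of group at this aromatic carbon alters the cytotoxicity read-out at all.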